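The compounds below may be only part of what the source reports. "The series", "measured", "known", "first", "only" and "open" are said of these compounds alone.

Compound 1 `COc1cc(C(=O)NS(=O)(=O)c2ccccc2C)ccc1Cc1cn(C)c2ccc(C(=O)NCC3CCCC3)cc12` carries a (cyclopentylmethyl)carbamoyl group on its core, and in an assay on isolated protein for binding affinity to cysteinyl leukotriene receptor 1 (Cavia porcellus) (on this read-out higher numbers stand for higher potency (the scale is a negative logarithm) and lower numbers for lower potency), compound 1 gives 8.4. Of the two numbers measured, compound 1 has the higher one; its nearest neighbour is compound 2 `C=CCn1cc(Cc2ccc(C(=O)NS(=O)(=O)c3ccccc3C)cc2OC)c2cc(C(=O)NCC3CCCC3)ccc21`, which in this assay gives 8.3, and the step of a number 0.10 log units lower from compound 1 to compound 2 (within the scatter) shows that the change at the aromatic nitrogen makes no difference beyond the scatter.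

Compound 3 `COc1cc(C(=O)NS(=O)(=O)c2ccccc2C)ccc1Cc1cn(C)c2ccc(NC(=O)CC3CCCC3)cc12` differs from compound 1 in another place: ((cyclopentylmethyl)carbonyl)amino in place of (cyclopentylmethyl)carbamoyl on an aromatic carbon. Among the compounds with values here, none of the measured steps touches this part of the molecule, so there is no step that bears directly on the reversal of the amide; the only measured step, from compound 1 to compound 2, concerns a different site and was within the scatter. With nothing to indicate a large change, a small loss is expected for compound 3, a step of a number 0.40 log units lower from compound 1 to compound 3 (beyond the scatter), giving an estimated value of 8 with a range from 7.2 to 8.7.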

Compound 3, negative logarithm of the antagonist equilibrium constant: 9.7
Compound 3: the middle estimate sits 1.70 log units below what was measured; measured number outside the range, above it.
By their numbers in this assay, from the lowest: compounds 2 and 1 (each within the scatter of the next); then compound 3.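

Reversing the amide on the aromatic carbon, with the same atoms joined differently, moves the number beyond the scatter in this assay (a number 1.30 log units higher from compound 1 to compound 3 (beyond the scatter)). This is the first change among these compounds to do so, as the change at the aromatic nitrogen in compound 2 stayed within the scatter. The direction in which the amide is joined to the core therefore matters at this position, even though the entering and leaving groups have the same counts of atoms, donors and acceptors, and nothing available explains why the reversed form gives the higher number.

Going by these compounds, it remains open whether a urea at this aromatic carbon, or a longer chain in place of cyclopentylmethyl on the reversed amide, would keep this gain. On these data alone, it is also open whether an allyl group on the aromatic nitrogen would be tolerated with the reversed amide as it is in compound 2.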